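Chain extension by one carbon in a sigma-1 series

The source may report more compounds than this note shows. Statements on the series, on what has been measured and on what is new or still open speak of the compounds shown alone.

Measured compounds:
- compound 1, `CCC(=O)c1ccc2c(c1)sc(=O)n2CCCCCN1CCCCCC1`: 12.2 nM
- compound 2, `CCC(=O)c1ccc2c(c1)sc(=O)n2CCCCCCN1CCCCCC1`: 10.4 nM
- compound 3, `CCCC(=O)c1ccc2c(c1)sc(=O)n2CCCN1CCCCCC1`: 2.6 nM

All three were tested in an assay on cell membranes for displacement of a labelled ligand from Sigma non-opioid intracellular receptor 1 (Rattus norvegicus); on this read-out lower numbers stand for stronger inhibition and higher numbers for weaker inhibition. Compound 1 gives 12.2 nM and compound 2 gives 10.4 nM. The two differ by a single change, ((azepan-1-yl)methyl in place of azepan-1-yl on a saturated chain carbon, five bonds along the chain from an aromatic nitrogen), and the step of a 1.2-fold lower number from compound 1 to compound 2 (0.07 log units; within the scatter) is small enough that the two numbers cannot be told apart. Compound 3 stands apart with 2.6 nM, the lowest of the three numbers; its gaps to compound 2 and to compound 1 both lie beyond the scatter. The difference between the core of compound 3 and the core of compound 1 is not broken down here.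

Compound 4, `CCCC(=O)c1ccc2c(c1)sc(=O)n2CCCCN1CCCCCC1`, has not yet been measured in this assay. It comes from compound 3 by (azepan-1-yl)methyl in place of azepan-1-yl on a saturated chain carbon, three bonds along the chain from an aromatic nitrogen. Going by the values given here, this is the same kind of change as the one from compound 1 to compound 2, though not the same: there the place was five bonds along the chain from an aromatic nitrogen, here it is three bonds along the chain. Since the earlier step was a 1.2-fold lower number from compound 1 to compound 2 (0.07 log units; within the scatter), a step of similar size is expected here, so the estimated step is no change at the digits printed from compound 3 to compound 4 (within the scatter). The estimate rests only on compound 3 with 2.6 nM and on that single earlier step, and the change of place adds uncertainty. For compound 4 the expected value in this assay is 2.6 nM, with a likely range from 1.1 nM to 6.5 nM.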

Compound 4, inhibition constant: 4.8 nM
For compound 4 the middle estimate is 1.8-fold (0.27 log units) below the measured one, within the range that was stated.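

In this assay, replacing azepan-1-yl with (azepan-1-yl)methyl at the place three bonds along the chain from an aromatic nitrogen gives a 1.8-fold higher number from compound 3 to compound 4 (0.27 log units; within the scatter), so this step cannot be told apart from the scatter of repeated measurements. Set beside the earlier step on the other core, the new step does not differ from it in any way the data can resolve: the same change on two cores in this assay, a 1.2-fold lower number (0.07 log units; within the scatter) from compound 1 to compound 2 and a 1.8-fold higher number (0.27 log units; within the scatter) from compound 3 to compound 4, 2.2-fold (0.34 log units) apart, within the scatter of two such steps. Going by these compounds alone, this shows that the change carried over between these two cores without a step beyond the scatter, but it rests on only two pairs of compounds, which also differ in where the change sits on the chain, and it does not show that the change has no effect at all or that the same would hold on any other core.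

The compounds shown leave open how the same change would behave with a piperidine or morpholine ring in place of the azepane ring, or with a much longer chain. They also leave open whether it would hold with an amide in place of the ketone on the shared ring system, since every compound here keeps a ketone at that site.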